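A few compounds are considered here, and "the series" means these few. Any claim that something is new, unique, unknown or untested is made for them only; others in the source may bear on it.

Working notes on the series. Compound 1 `c1cn2cc(-c3ccsc3)nc(-c3ccc4ncn(C5CCCCC5)c4c3)c2n1` and compound 2 `CC(=O)c1ccc(-c2cn3ccnc3c(-c3ccc4ncn(C5CCCCC5)c4c3)n2)cc1` share one core and differ only in the aryl group. In a functional assay on MDA-MB-231 cells (Homo sapiens) for inhibition, read by sulforhodamine B assay, with a stated time of 48 h, tested at 10 uM (on this read-out lower numbers stand for less inhibition and higher numbers for more inhibition at the one concentration tested (going by the name of the read-out)), compound 1 gives 1.35%. Compound 2 in this assay gives 7.65%; of the two numbers measured, its nearest neighbour is compound 1, and the step of a number 6.3 percentage points higher from compound 1 to compound 2 (within the scatter) lies within the scatter. Compound 3 `FC(F)(F)c1cccc(-c2cn3ccnc3c(-c3ccc4ncn(C5CCCCC5)c4c3)n2)c1` is not yet measured and carries 3-(trifluoromethyl)phenyl in place of 4-acetylphenyl on an aromatic carbon. Among the compounds with values here, only that one aryl swap bears on this change, and it was small, so no step beyond the scatter is expected in this assay. For compound 3 a value of 5% is expected, between -5% and 15%. The step expected from this change is a number 2.7 percentage points lower from compound 2 to compound 3 (within the scatter).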

Compound 3, a percentage reported as inhibition, at one concentration (the size of the read-out at that concentration, not a potency): 21.8%
Compound 3: the middle estimate sits 16.8 percentage points below what was measured; the measured number lies above the stated range.
By their numbers in this assay, from the lowest: compounds 1 and 2 (each within the scatter of the next); then compound 3.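

In this assay, the swap to 3-(trifluoromethyl)phenyl gives a number 14.2 percentage points higher from compound 2 to compound 3 (beyond the scatter) and a number 20.5 percentage points higher from compound 1 to compound 3 (beyond the scatter). The aryl group at this position can therefore move the read-out beyond the scatter, which the step between the earlier two compounds did not show. No evidence available here accounts for this change. Compound 2 and compound 3 differ in both the substituent and its place on the phenyl ring, so the two remain unseparated. From the compounds shown here alone, how an amine or a carboxylic acid on that phenyl ring would read remains open.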